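Dropping the Acid from a Weak Cell-Growth Inhibitor

The source may hold more compounds than are shown below. What is called first, only, known or untested is meant among the compounds shown, and "the series" means these compounds.

Compound 1 `O=C(O)c1cccc(COc2ccc(OCCOCCNC3CCCC3)cc2)c1` belongs to a small set tested in a functional assay on SK-OV-3 cells (Homo sapiens) for inhibition, read by CCK-8 assay, with a stated time of 70 h; on this read-out higher numbers stand for weaker inhibition and lower numbers for stronger inhibition. In this assay compound 1 gives > 100000 nM, which is a limit of the assay rather than a measured number, so compound 1 sits at the weak end of what the assay can report (the limit of > 100000 nM in this assay, at which 1 of the 2 values shown sits). A second member of the set, compound 2 `c1ccc(COc2ccc(OCCOCCNc3cc[nH]c3)cc2)cc1`, was measured as a full number; in this assay compound 2 gives 11300 nM. Within the data shown here, no pair of measured compounds differs in a single place, so the effect of any one change cannot be read off directly from these two values.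

Compound 3 `Cc1ccc(COc2ccc(OCCOCCNC3CCCC3)cc2)cc1` is the compound not yet measured. It differs from compound 1 in one place: 4-methylphenyl in place of 3-carboxyphenyl on a saturated chain carbon bound to an oxygen on an aromatic ring. Because compound 1 sits at the limit (the limit of > 100000 nM in this assay, at which 1 of the 2 values shown sits), only a gain in inhibition or no change at all can show up, and a gain beyond the usual scatter is expected, an at least 3.3-fold lower number from compound 1 to compound 3 (0.52 log units; beyond the scatter). Compound 3 is therefore expected to give about 30000 nM in this assay, within a range from 8000 nM to 100000 nM.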

Compound 3, half-maximal inhibitory concentration: 17200 nM
Compound 3: the middle estimate sits 1.7-fold (0.24 log units) above what was measured; low and high end bracket the measured number.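

Replacing 3-carboxyphenyl with 4-methylphenyl on a saturated chain carbon bound to an oxygen on an aromatic ring gives, in this assay, an at least 5.8-fold lower number from compound 1 to compound 3 (0.76 log units; beyond the scatter), which shows that this place on the shared core responds to the group it carries. Among these compounds, the earlier compounds could not show this, as no two of them differed in one place only, so this is the first single change that can be read directly. The printed step gives only the smallest possible size of the change, because the starting point is a limit of the assay for compound 1 and not a measured number: the limit of > 100000 nM in this assay, at which 1 of the 3 values shown sits.

The step swaps the carboxylic acid for a methyl and also alters the numbered ring location of the substituent, so the compounds shown cannot say whether losing the acid, gaining the methyl, or the new location accounts for the gain. Comparing a 3-methylphenyl or a 4-carboxyphenyl in the same place would help separate these effects, and a 4-chlorophenyl would test whether methyl itself matters.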